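Chain terminus swap on the fluoroindole series

This account rests on a few compounds, and the source may have more. Where it says the series, first, only, none or still open, it means among the compounds named here.

Measured compounds:
compound 1, `NC(=O)CCCCc1c[nH]c2ccc(F)cc12`, 43 nM in an assay on isolated protein for inhibition of Myeloperoxidase (Homo sapiens), read by ELISA, with a stated time of 5 min; a higher number here means a weaker inhibitor, a lower number a stronger inhibitor
compound 2, `NCCSCCc1c[nH]c2ccc(F)cc12`, 8 nM
compound 3, `NCCSCCCc1c[nH]c2c(F)cccc12`, > 100 nM, a limit of the assay, not a number

Compound 2 holds the lowest of the two numbers shown; its nearest neighbour is compound 1, separated by a 5.4-fold lower number from compound 1 to compound 2 (0.73 log units; beyond the scatter). For compound 3 only a limit is reported, (the limit of > 100 nM in this assay, at which 1 of the 3 values shown sits).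

Compound 4, `NC(=O)CCc1c[nH]c2ccc(F)cc12`, is not yet measured. It differs from compound 2 by carbamoyl in place of (2-aminoethyl)sulfanyl on a saturated chain carbon, two bonds along the chain from an aromatic carbon. For the measured compounds named here, the only measured step that bears on this change runs in the other direction: replacing a carbamoyl-bearing chain end with the (2-aminoethyl)sulfanyl end gave a 5.4-fold lower number from compound 1 to compound 2 (0.73 log units; beyond the scatter). Compound 4 removes that same (2-aminoethyl)sulfanyl end and puts a carbamoyl in its place, so in this assay a step of similar size toward a higher number is expected, with the limit of the assay within reach.

Compound 4 is therefore expected to give 120 nM, in the range 35 nM to 500 nM, an estimated step of a 15-fold higher number from compound 2 to compound 4 (1.18 log units; beyond the scatter).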

Compound 4, half-maximal inhibitory concentration: 34 nM
Compound 4: middle estimate off by 3.5-fold (0.55 log units), on the high side; the measured number lies below the stated range.
By their numbers in this assay, from the lowest: compound 2; then compounds 4 and 1 (each within the scatter of the next). At a limit, above all of these: compound 3.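

In this assay, the carbamoyl end on the shorter chain runs opposite to the earlier gain, with a 4.3-fold higher number from compound 2 to compound 4 (0.63 log units; beyond the scatter), so that gain is not confined to the longer carbamoyl chain as the comparison partner. Trimming the carbamoyl side chain leaves no change that can be told from noise, with a 1.3-fold lower number from compound 1 to compound 4 (0.10 log units; within the scatter), so across these two chain lengths the carbamoyl compounds show no dependence on chain length. Nothing measured here accounts for the gap between the (2-aminoethyl)sulfanyl end and the carbamoyl end.

Still open, going by these compounds, is whether the sulfur or the amine of the (2-aminoethyl)sulfanyl end carries the difference. A plain aminoalkyl chain, a methylsulfanyl end or a carboxylic acid end on the same core would separate these.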